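A few compounds are considered here, and "the series" means these few. Any claim that something is new, unique, unknown or untested is made for them only; others in the source may bear on it.

Two compounds with a closely related core have numbers in an ADME assay on microsomes (Mus musculus) for metabolic stability; a lower number here means slower removal, a higher number faster removal of the compound. Compound 1 `CCc1cc(C(F)(F)F)c2cccc(OCc3c(Cl)ccc(S(=O)(=O)N4CCC[C@H]4C(=O)NC)c3Cl)c2n1` gives 1280 mL/min/kg, and compound 2 `Cc1cc(C(F)(F)F)c2cccc(OCc3c(Cl)ccc(S(=O)(=O)N4CCC[C@H]4CO)c3Cl)c2n1` gives 1630 mL/min/kg. These two values lie within the scatter of each other, so compound 2 stands level with compound 1 on this evidence. Compound 3 `Cc1cc(C(F)(F)F)c2cccc(OCc3c(Cl)ccc(S(=O)(=O)N4CCC(CCO)CC4)c3Cl)c2n1` keeps the core of compound 2 but carries 4-(2-hydroxyethyl)piperidin-1-yl in place of 2-(hydroxymethyl)pyrrolidin-1-yl on a sulfonyl sulfur. For the measured compounds named here, no measured pair isolates a change of this kind, so the data offer no direct guide to its size or direction. With only the two similar values to go on, no change beyond the scatter is expected in this assay. The expected change is a 1.1-fold lower number from compound 2 to compound 3 (0.04 log units; within the scatter), which stays within the scatter. The clearance of compound 3 is estimated at 1500 mL/min/kg, with an expected range from 800 mL/min/kg to 2500 mL/min/kg.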

Compound 3, clearance: 1080 mL/min/kg
For compound 3 the middle estimate is 1.4-fold (0.14 log units) above the measured one; measured number inside the range.
By their numbers in this assay, from the lowest: compounds 3, 1 and 2 (each within the scatter of the next).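

In this assay, for the compounds shown here, the swap of 2-(hydroxymethyl)pyrrolidin-1-yl for 4-(2-hydroxyethyl)piperidin-1-yl on a sulfonyl sulfur gives a 1.5-fold lower number from compound 2 to compound 3 (0.18 log units; within the scatter) and is the first single-place step at this position. It shows that this position accepts a six-membered ring with a 2-hydroxyethyl chain without a change in clearance beyond the scatter, while the defined stereocentre of the leaving group is also lost. Nothing available bears on why the number behaves this way.

Ring size, chain length and the stereocentre all change together in this one step, so their separate contributions remain open. Also open, from the compounds shown here alone, is whether a group of another kind at this sulfonyl sulfur, such as a morpholine or a piperidine bearing a carboxylic acid, would move the clearance beyond the scatter.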